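Sulfonyl aryl change on the shortest-lived compound

The compounds below may be only part of what the source reports. "The series", "measured", "known", "first", "only" and "open" are said of these compounds alone.

In an ADME assay on the whole organism (Rattus norvegicus, strain Sprague-Dawley), read by LC-MS, with a stated time of 30 min, at a dose of 1 mg/kg by the intravenous route (on this read-out higher numbers stand for a longer-lived compound and lower numbers for a shorter-lived compound), compound 1 (`N#Cc1ccc(O[C@H]2CN(S(=O)(=O)c3ccc(Cl)cc3Cl)C[C@@]2(O)CN)cc1F`) gives 3.2 h and compound 2 (`N#Cc1ccc(O[C@H]2CN(S(=O)(=O)c3ccc(Cl)cc3Cl)C[C@]2(O)CO)cc1F`) gives 4.8 h. Compound 3 (`N#Cc1ccc(O[C@H]2CN(S(=O)(=O)c3ccccc3C#N)C[C@@]2(O)CO)cc1F`) gives 0.4 h, the lowest of the three, with both gaps beyond the scatter. Compound 4 (`N#Cc1ccc(O[C@H]2CN(S(=O)(=O)c3ccc(Cl)cc3)C[C@@]2(O)CO)cc1F`) carries 4-chlorophenyl in place of 2-cyanophenyl on a sulfonyl sulfur. Among the compounds with values here, no measured pair isolates this change. Compound 1 at 3.2 h and compound 2 at 4.8 h also carry chlorine on the aryl group on the sulfonyl sulfur, although they differ elsewhere too, so a rise beyond the scatter is expected. The expected change is a 4.5-fold higher number from compound 3 to compound 4 (0.65 log units; beyond the scatter). For compound 4, the estimated value is 1.8 h, with an expected range of 0.7 h to 4.5 h.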

Compound 4, mean residence time in the Rattus norvegicus assay: 1.9 h
For compound 4 the middle estimate is 1.1-fold (0.02 log units) below the measured one; measured number inside the range.
By their numbers in the Rattus norvegicus assay, from the lowest: compound 3; then compounds 4, 1 and 2 (each within the scatter of the next, the first and the last beyond it).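

Within the data shown here, in the Rattus norvegicus assay, 4-chlorophenyl in place of 2-cyanophenyl on a sulfonyl sulfur gives a 4.8-fold higher number from compound 3 to compound 4 (0.68 log units; beyond the scatter), the first reading of this position with only the aryl group changed. The longer residence comes with higher lipophilicity in a physicochemical assay for lipophilicity, at pH 7.4; on this read-out higher numbers stand for higher lipophilicity and lower numbers for lower lipophilicity (compound 3 gives 3.4 and compound 4 gives 4.1), although a single pair cannot show that one drives the other: the measured distribution coefficient of compound 3, 3.4, and of compound 4, 4.1, a number 0.70 log units higher (beyond the scatter)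

As far as these compounds go, whether the step follows the arrival of the chlorine or the loss of the nitrile remains open. Unsubstituted phenyl or 4-methoxyphenyl on the sulfonyl sulfur would help to separate these two readings.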